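The source may hold more compounds than are shown below. What is called first, only, known or untested is meant among the compounds shown, and "the series" means these compounds.

Compound 1 `CCN1CCN(c2ccc(Nc3ncc(Cl)c(Nc4ccccc4C)n3)nc2)CC1` and compound 2 `Cc1ccccc1Nc1nc(Nc2ccc(N3CCCCC3)cn2)ncc1Cl` share one core and differ at a single point: piperidin-1-yl in place of 4-ethylpiperazin-1-yl on an aromatic carbon. In an ADME assay on L02 cells (Homo sapiens) for inhibition, read by CCK-8 assay, with a stated time of 48 h (a higher number here means a weaker inhibitor of growth, a lower number a stronger inhibitor of growth), compound 1 gives only a limit, > 100000 nM, which is the limit of > 100000 nM in this assay, at which 1 of the 3 values shown sits. In this assay compound 2 gives 42400 nM, so that an at least 2.3-fold lower number from compound 1 to compound 2 (0.37 log units; beyond the scatter). Compound 3 `CCN1CCN(c2ccc(Nc3ncc(Cl)c(Nc4ccccc4C)n3)cc2)CC1` carries the 4-ethylpiperazin-1-yl group of compound 1 on another core; the difference between the two cores is not broken down here. In this assay compound 3 gives 970 nM, the lower of the two measured numbers, beyond the scatter from compound 2.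

Compound 4 `Cc1ccccc1Nc1nc(Nc2ccc(N3CCCCC3)cc2)ncc1Cl` is not yet measured. It stands to compound 3 as compound 2 stands to compound 1: piperidin-1-yl in place of 4-ethylpiperazin-1-yl on an aromatic carbon. The surroundings differ: in compounds 1 and 2 the group sits on a six-membered aromatic ring with 1 nitrogen, two atoms from the ring nitrogen, para to a large group, whereas in compounds 3 and 4 it sits on a six-membered aromatic ring of carbon only, para to a large group; so this is the same kind of change, not the same. Because an at least 2.3-fold lower number from compound 1 to compound 2 (0.37 log units; beyond the scatter) brought a lower number, compound 4 is expected to show a step of about a 1.9-fold lower number from compound 3 to compound 4 (0.29 log units; within the scatter) in this assay. Compound 4 is therefore estimated at 500 nM, expected to lie between 150 nM and 2000 nM.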

Compound 4, concentration for 50% growth inhibition: 5690 nM
Compound 4: middle estimate off by 11-fold (1.06 log units), on the low side; measured number outside the range, above it.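

In this assay, piperidin-1-yl in place of 4-ethylpiperazin-1-yl gives a 5.9-fold higher number from compound 3 to compound 4 (0.77 log units; beyond the scatter), so on this core the change runs in the opposite direction to the step on the core of compound 1, and the two steps do not agree: the same change on two cores in this assay, an at least 2.3-fold lower number (0.37 log units; beyond the scatter) from compound 1 to compound 2 and a 5.9-fold higher number (0.77 log units; beyond the scatter) from compound 3 to compound 4, at least 13-fold (1.14 log units) apart, beyond the scatter of two such steps. The value of compound 1 is a limit, so the earlier step gives only a bound on its size: the limit of > 100000 nM in this assay, at which 1 of the 4 values shown sits. Across these two pairs, the direction of this change did not carry from one core to the other, but two pairs cannot show which difference between the cores goes with the reversal, or how the change would run on any further core.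

The compounds shown leave open how other groups in the same place, such as morpholin-4-yl or an open-chain amine like dimethylamino, would read in this assay on either core. They also leave open whether a group such as 4-methylpiperazin-1-yl would follow compound 3 or compound 4 on the carbon-only ring.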